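A larger aryl group on the more soluble compound

This account rests on a few compounds, and the source may have more. Where it says the series, first, only, none or still open, it means among the compounds named here.

Compound 1 `CCc1ccc(-c2nc3c(c(C)nn3-c3ccccc3)c(-c3ccccc3F)c2C#N)cc1`: 1700 nM
Compound 2 `Cc1ccc(-c2nc3c(c(C)nn3-c3ccccc3)c(-c3ccccc3O)c2C#N)cc1`: 26000 nM

Both values come from a physicochemical assay for solubility, read by spectrophotometry, in phosphate buffer, with a stated time of 18 h, at pH 7.4; on this read-out higher numbers stand for higher solubility and lower numbers for lower solubility. Compound 2 stands higher of the two at 26000 nM, beyond the usual scatter from the other measured compound. Going by the values given here, the two compounds differ in more than one place, so no measured pair isolates a single change.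

Compound 3 `Cc1nn(-c2ccccc2)c2nc(-c3ccc4ccccc4c3)c(C#N)c(-c3ccccc3O)c12` keeps the rest of compound 2 but carries naphthalen-2-yl in place of 4-methylphenyl on an aromatic carbon, ortho to a cyano group: naphthalen-2-yl in place of 4-methylphenyl on an aromatic carbon. Among the compounds with values here, no measured step speaks directly to this swap, so the expectation in this assay is a judgement: a downward step of moderate size, somewhat beyond the scatter. Within the data shown here, the only guide to how low a close relative of compound 2 can lie is compound 1 at 1700 nM. The estimated change is a 3.7-fold lower number from compound 2 to compound 3 (0.57 log units; beyond the scatter). For compound 3 the expected value is 7000 nM, with an estimated range of 1800 nM to 22000 nM.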

Compound 3, solubility: 1800 nM
Estimate against measurement, compound 3: 3.9-fold (0.59 log units) above; measured number inside the range.
By their numbers in this assay, from the lowest: compounds 1 and 3 (each within the scatter of the next); then compound 2.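

In this assay, going by these compounds alone, naphthalen-2-yl in place of 4-methylphenyl, ortho to a cyano group, gives a 14-fold lower number from compound 2 to compound 3 (1.16 log units; beyond the scatter) and provides the first measured step between compounds that differ in one place. It shows that the number in this assay is sensitive to the aryl group at this position: with the 2-hydroxyphenyl group and the rest of the core unchanged, replacing one six-membered aromatic ring of carbon only with two carries the value well beyond the scatter, although neither group has a hydrogen-bond donor or acceptor. Nothing measured here explains the size of this step.

A single swap cannot show whether the second ring or the added carbon count matters more, or whether a pyridin-3-yl ring, a morpholine or a carboxylic acid on an aryl group at this position would give a higher or lower number. It also leaves open whether the same swap would give a step of similar size on a core carrying 2-fluorophenyl in place of 2-hydroxyphenyl.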